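The source may hold more compounds than are shown below. What is called first, only, known or untested is meant among the compounds shown, and "the series" means these compounds.

Measured compounds in a functional assay on MCF7 cells (Homo sapiens) for inhibition, read by MTT assay, with a stated time of 48 h, tested at 15 ug/mL; a lower number here means less inhibition of growth, a higher number more inhibition of growth at the concentration tested:
- compound 1 `O=c1cc(-c2ccccc2)oc2ccc(N3COc4c(Br)cc(Br)cc4C3)cc12`: 13.6%
- compound 2 `O=c1cc(-c2ccccc2)oc2cc(N3COc4c(Br)cccc4C3)ccc12`: 5.64%
- compound 3 `O=c1cc(-c2ccccc2)oc2ccc(N3COc4c(Br)cccc4C3)cc12`: 37.8%

Compound 2 stands lowest of the three numbers. Its nearest neighbour is compound 1, which lies within the scatter of it; compound 3 lies beyond the scatter, higher. Between compound 1 and compound 3 the only change is hydrogen in place of bromo on an aromatic carbon, and this gave a number 24.2 percentage points higher from compound 1 to compound 3 (beyond the scatter).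

Compound 4 `O=c1cc(-c2ccccc2)oc2cc(N3COc4c(Br)cc(Br)cc4C3)ccc12` is unmeasured. From compound 2 it differs by bromo in place of hydrogen on an aromatic carbon. This is the reverse of the change from compound 1 to compound 3, applied on the core of compound 2 rather than on the core of compound 3. That measured step is the only one that bears on it, and it was modest, running towards higher inhibition when the bromo was removed; adding the bromo here would point the other way. Compound 2 already gives 5.64%, so there is little room downward, and the two cores of the series need not behave alike.

For compound 4 a step of a number 1.6 percentage points lower from compound 2 to compound 4 (within the scatter) is therefore expected, within the scatter. Compound 4 is estimated at 4%, with a range of 0% to 14%.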

Compound 4, percent growth inhibition at one concentration: 1.64%
Beside the measured number, compound 4's estimate is 2.4 percentage points above it; the range from low to high includes it.
By their numbers in this assay, from the lowest: compounds 4, 2 and 1 (each within the scatter of the next, the first and the last beyond it); then compound 3.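

In this assay, bromo in place of hydrogen on this aromatic carbon, meta to a bromo group and para to a fused ring, gives a number 4 percentage points lower from compound 2 to compound 4 (within the scatter), so on this core the change has no readable effect. Going by these compounds alone, until now the only reading of this change came from the other core, where removing the bromo raised the number beyond the scatter, and that effect does not carry over to this core. For these two pairs, the size of the step depends on the core that carries it: the same change on two cores in this assay, a number 24.2 percentage points higher (beyond the scatter) from compound 1 to compound 3 and a number 4 percentage points higher (within the scatter) from compound 4 to compound 2, 20.2 percentage points apart, beyond the scatter of two such steps

As far as these compounds go, the two pairs hold only hydrogen or bromo on this carbon, so it stays open whether a chloro group, a methoxy group or an amine there would separate the two cores in the same way. From the compounds shown here alone, it also stays open whether compound 2 and compound 4 would remain this weak across a range of concentrations, as a single tested concentration gives no dose response.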